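The source may hold more compounds than are shown below. What is called first, only, known or untested is meant among the compounds shown, and "the series" means these compounds.

Measured compounds:
Compound 1, `COC(=O)N(C)CC#CCN1CCCC1`: 1.4 mg/kg
Compound 2, `COC(=O)N(C)CC#CCn1ccnc1`: 2 mg/kg
Compound 3, `COC(=O)N(C)C(C)C#CCn1ccnc1`: 6.6 mg/kg

All three were tested in a functional assay on the whole organism for agonist activity, with Mus musculus as the target; a lower number here means that less compound is needed, a higher number that more compound is needed for the effect. Compound 1 gives the lowest number of the three, though its gap to compound 2 is a 1.4-fold higher number from compound 1 to compound 2 (0.15 log units; within the scatter) and so is not read as an order. The two cores differ in this way: pyrrolidin-1-yl in place of 1H-imidazol-1-yl on a saturated chain carbon bound to a triple-bonded carbon. Within the core of compound 2, one change has been measured: methyl in place of hydrogen on a saturated chain carbon bound to an amide-type nitrogen and a triple-bonded carbon, which gave a 3.3-fold higher number from compound 2 to compound 3 (0.52 log units; beyond the scatter).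

Compound 4, `CCOC(=O)N(C)CC#CCN1CCCC1`, has not been measured. Relative to compound 1 it carries methyl in place of hydrogen on a saturated chain carbon bound to an oxygen next to a carbonyl group. This is the same kind of change as from compound 2 to compound 3, but not the same change, since the places differ: in compound 3 the methyl sits on a saturated chain carbon bound to an amide-type nitrogen and a triple-bonded carbon, whereas in compound 4 it sits on a saturated chain carbon bound to an oxygen next to a carbonyl group, the methoxycarbonyl becoming an ethoxycarbonyl.

In this assay the step from compound 1 to compound 4 is expected to be a 1.4-fold higher number from compound 1 to compound 4 (0.15 log units; within the scatter), set beside a 3.3-fold higher number from compound 2 to compound 3 (0.52 log units; beyond the scatter). Within the data shown here, that expectation rests on the single measured methyl-for-hydrogen step, a 3.3-fold higher number from compound 2 to compound 3 (0.52 log units; beyond the scatter), having come from a different place, so only part of its size is carried over. Compound 4 is therefore expected to give about 2 mg/kg in this assay, estimated to lie between 0.8 mg/kg and 5.5 mg/kg.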

Compound 4, dose for half-maximal effect: 66 mg/kg
Compound 4: middle estimate off by 33-fold (1.52 log units), on the low side; measured number outside the range, above it.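

Putting a methyl on the saturated chain carbon bound to an oxygen next to a carbonyl group, which turns the methoxycarbonyl into an ethoxycarbonyl, gave a 47-fold higher number from compound 1 to compound 4 (1.67 log units; beyond the scatter) in this assay. Both methyl-for-hydrogen steps measured in this series run towards a higher number, but their sizes do not match, so the size of one could not be carried over to the other: the same change on two cores in this assay, a 3.3-fold higher number (0.52 log units; beyond the scatter) from compound 2 to compound 3 and a 47-fold higher number (1.67 log units; beyond the scatter) from compound 1 to compound 4, 14-fold (1.15 log units) apart, beyond the scatter of two such steps. This does not show whether the core or the place of the methyl accounts for the gap, as the two steps differ in both, and each rests on a single pair of compounds.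

The compounds shown leave open what the ethoxycarbonyl would do on the core of compound 2, and what a methyl on the saturated chain carbon bound to an amide-type nitrogen and a triple-bonded carbon would do on the core of compound 1, the two pairings that would separate core from place. They also leave open whether a propoxycarbonyl or a longer chain in place of the ethoxycarbonyl would continue the rise in the number.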